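The source may hold more compounds than are shown below. What is called first, only, known or untested is meant among the compounds shown, and "the series" means these compounds.

Working notes on the series in a functional assay on MT4 cells (Homo sapiens) for antiproliferative activity, read by MTT assay, with a stated time of 96 h; a higher number here means a weaker inhibitor, a lower number a stronger inhibitor.

Compound 1 `CN(C)c1ccc(N2C(=O)NC3(CSC4=C3C(=O)c3ncccc3C4=O)C2=O)cc1` gives 15 nM in this assay, the highest of the three numbers in hand. Compound 2 `O=C1C2=C(C(=O)c3ncccc31)C1(CS2)NC(=O)N(c2ccc([N+](=O)[O-])cc2)C1=O` gives 8 nM, and compound 3 `CCN(CC)c1ccc(N2C(=O)NC3(CSC4=C3C(=O)c3ncccc3C4=O)C2=O)cc1` gives 8 nM. The two steps from compound 1 are a 1.9-fold lower number from compound 1 to compound 2 (0.27 log units; within the scatter) and a 1.9-fold lower number from compound 1 to compound 3 (0.27 log units; within the scatter), and between the other pair no change at the digits printed from compound 2 to compound 3 (within the scatter); none of the three leaves the scatter, so the three measured compounds cannot be ordered.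

Compound 4 `CCCCCc1ccc(N2C(=O)NC3(CSC4=C3C(=O)c3ncccc3C4=O)C2=O)cc1` differs from compound 1 in one place: pentyl in place of dimethylamino on an aromatic carbon. Going by the values given here, no measured step puts a pentyl at this position, so the expectation rests on the two steps that do alter the same position, which were within the scatter in both cases. The estimate for compound 4 is therefore a step of no change at the digits printed from compound 1 to compound 4 (within the scatter), with no change beyond the scatter expected. Among the compounds with values here, compound 4 is expected to give about 15 nM in this assay, within a range of 5 nM to 45 nM; the range is widened since the pentyl itself has no precedent.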

Compound 4, half-maximal inhibitory concentration: 190 nM
Estimate against measurement, compound 4: 13-fold (1.10 log units) below, outside the stated range (above it).
By their numbers in this assay, from the lowest: compounds 2, 3 and 1 (each within the scatter of the next); then compound 4.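

In this assay this position proves sensitive to the group it carries: the swaps among dimethylamino, diethylamino and nitro all stayed within the scatter, whereas pentyl brings a 13-fold higher number from compound 1 to compound 4 (1.10 log units; beyond the scatter) and a 24-fold higher number from compound 3 to compound 4 (1.38 log units; beyond the scatter) as well as a 24-fold higher number from compound 2 to compound 4 (1.38 log units; beyond the scatter) in the same series. Compound 4 is therefore the only one of the four that stands apart, and the earlier flat steps do not extend to every group at this aromatic carbon. No measurement in hand accounts for this loss.

From the compounds shown here alone, whether the loss belongs to the pentyl chain itself or to any all-carbon group at this position remains open from this single example. An ethyl or butyl chain, or a pentylamino group carrying the same chain through a nitrogen, would help separate those two readings.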